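The source may report more compounds than this note shows. Statements on the series, on what has been measured and on what is new or still open speak of the compounds shown alone.

Three measured compounds share a common core and carry nitrate-bearing chains on both the ester and the aromatic oxygen. Compound 1 `O=C(/C=C/c1ccc(OCCCCO[N+](=O)[O-])c(O)c1)OCCCCO[N+](=O)[O-]` carries a hydroxy on the aromatic ring and four-carbon chains. In a functional assay on NCI-H460 cells (Homo sapiens) for cytotoxicity, read by resazurin assay, with a stated time of 72 h (on this read-out higher numbers stand for weaker inhibition and lower numbers for stronger inhibition), compound 1 reaches only the limit of the assay, > 50000 nM. Compound 2 `O=C(/C=C/c1ccc(OCCCCCCO[N+](=O)[O-])c(O)c1)OCCCCCCO[N+](=O)[O-]` has six-carbon chains in place of the shorter ones; how its core differs from that of compound 1 is not broken down here. In this assay compound 2 also returns only a limit, > 50000 nM. Compound 3 `COc1cc(/C=C/C(=O)OCCCCO[N+](=O)[O-])ccc1OCCCCO[N+](=O)[O-]` differs from compound 1 by methyl in place of hydrogen on an oxygen on an aromatic ring. In this assay compound 3 likewise gives only a limit, > 50000 nM. For the measured compounds named here, the step that the two limits leave unreadable from compound 1 to compound 3 therefore cannot be sized, because the limit of > 50000 nM in this assay, at which 3 of the 3 values shown sit, is where every value so far sits.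

Compound 4 `COc1cc(/C=C/C(=O)OCCCCCCO[N+](=O)[O-])ccc1OCCCCCCO[N+](=O)[O-]` has not yet been measured. It differs from compound 2 by methyl in place of hydrogen on an oxygen on an aromatic ring, the same change that separates compound 1 from compound 3, and it sits at the same kind of place on the ring. Since compound 2 gives only a limit in this assay, and the same change in compound 3 stayed at the limit, the step from compound 2 to compound 4 is expected to be a step that the limit leaves unreadable from compound 2 to compound 4. Compound 4 is estimated to give 90000 nM in this assay, with an expected range from 30000 nM to 400000 nM, most likely reported again only as a limit.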

Compound 4, half-maximal inhibitory concentration: > 50000 nM
Compound 4: a limit, no number; the forecaster's own chance of this, stated with the estimate: 85%; the middle value lies beyond the limit too.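

In this assay compound 4 gives > 50000 nM, which is a limit and not a number. Compound 2 also stands only at a limit, so no step can be read between compound 2 and compound 4. The compounds shown leave open how far any of them lies past that limit, and so whether the change from hydroxy to methoxy alters the read-out at all: the limit of > 50000 nM in this assay, at which 4 of the 4 values shown sit.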